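The compounds below may be only part of what the source reports. "The series", "measured", "known", "first", "only" and "open" are said of these compounds alone.

Measured compounds:
compound 1, `NC(=O)CC1CCN(c2nc(-c3cc(F)c(Cl)cc3F)nc3c2CS(=O)(=O)C3)CC1`, 0.1 mg/kg
compound 2, `NC(=O)CCC1CCN(c2nc(-c3cc(F)c(Cl)cc3F)nc3c2CS(=O)(=O)C3)CC1`, 0.3 mg/kg
compound 3, `NC(=O)CN1CCN(c2nc(-c3cc(F)c(Cl)cc3F)nc3c2CS(=O)(=O)C3)CC1`, 3 mg/kg

All three were tested in a functional assay on the whole organism (blood, strain ICR) with Mus musculus as the target, in the glucose tolerance test, with a stated time of 30 min; a lower number here means that less compound is needed, a higher number that more compound is needed for the effect. Compound 3 stands at the highest number of the three; compound 2 lies below it and compound 1 further still, both gaps beyond the scatter. The two single-point steps are a 3.0-fold higher number from compound 1 to compound 2 (0.48 log units; beyond the scatter) and a 30-fold higher number from compound 1 to compound 3 (1.48 log units; beyond the scatter).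

Compound 4, `O=S1(=O)Cc2nc(-c3cc(F)c(Cl)cc3F)nc(N3CCC(CO)CC3)c2C1`, has not yet been measured in this assay. Its change from compound 3 is 4-(hydroxymethyl)piperidin-1-yl in place of 4-(carbamoylmethyl)piperazin-1-yl on an aromatic carbon.

The step given as a 30-fold higher number from compound 1 to compound 3 (1.48 log units; beyond the scatter) bears most directly on this change: putting 4-(carbamoylmethyl)piperazin-1-yl in place of 4-(carbamoylmethyl)piperidin-1-yl brought a large move upward, and compound 4 carries a piperidin-1-yl group again, as compound 1 does, so that move should largely be undone. Among the compounds with values here, the chain on that ring is also altered, from carbamoylmethyl to hydroxymethyl; the only step touching the chain, a 3.0-fold higher number from compound 1 to compound 2 (0.48 log units; beyond the scatter), was modest, and no measured compound carries a hydroxymethyl group, so that part remains open. Compound 4 is therefore expected to show a 10-fold lower number from compound 3 to compound 4 (1.00 log units; beyond the scatter), though not necessarily down to the number of compound 1. The estimate for compound 4 is 0.3 mg/kg, with a range from 0.1 mg/kg to 1 mg/kg.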

Compound 4, minimum effective dose: 0.3 mg/kg
The estimate for compound 4 equals the measured number at the digits printed; measured number inside the range.
By their numbers in this assay, from the lowest: compound 1; then compounds 2 and 4 (each within the scatter of the next); then compound 3.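

In this assay, 4-(hydroxymethyl)piperidin-1-yl in place of 4-(carbamoylmethyl)piperazin-1-yl on this aromatic carbon gives a 10-fold lower number from compound 3 to compound 4 (1.00 log units; beyond the scatter), so a piperidin-1-yl group can stand well below compound 3 without any carbamoyl group on its chain. Hydroxy at the end of the chain gives no change at the digits printed from compound 2 to compound 4 (within the scatter), which shows that a carbamoyl group is not required to reach this level, while the comparison with the carbamoylmethyl compound gives a 3.0-fold higher number from compound 1 to compound 4 (0.48 log units; beyond the scatter), leaving compound 1 with the lowest number of the four. Nothing measured here accounts for these differences.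

The compounds shown leave open whether an amine or a carboxylic acid at the end of the chain on the piperidin-1-yl ring would hold this level, and whether a longer chain ending in hydroxy would follow the carbamoyl pair. They also leave open how a 2-hydroxyethyl group on the piperazin-1-yl ring would compare, which would help separate the effect of the ring from that of the chain.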